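The source may report more compounds than this note shows. Statements on the series, on what has been measured and on what is new or still open speak of the compounds shown alone.

In a functional assay on A-431 cells (Homo sapiens) for antiproliferative activity, read by CCK-8 assay, with a stated time of 72 h (a higher number here means a weaker inhibitor, a lower number a stronger inhibitor), compound 3 `C#Cc1cccc(Nc2ncnc3cc(OCCOC)c(OCCOC(=O)c4ccccc4OC(C)=O)cc23)c1` gives > 10000 nM, which is a limit and not a number. Compound 2 `C#Cc1cccc(Nc2ncnc3cc(OCCOC(=O)c4ccccc4OC(C)=O)c(OCCOC(=O)c4ccccc4OC(C)=O)cc23)c1` gives > 10000 nM, also a limit. Among the compounds with values here, compound 1 `C#Cc1cccc(Nc2ncnc3cc(OCCOC(=O)C(C)c4ccc5cc(OC)ccc5c4)c(OCCOC)cc23)c1` gives 3200 nM, the only true number so far.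

Compound 4 `C#Cc1cccc(Nc2ncnc3cc(OCCOC)c(OCCOC(=O)C(C)c4ccc(CC(C)C)cc4)cc23)c1` departs from compound 3 as follows: 1-(4-isobutylphenyl)ethyl in place of 2-acetoxyphenyl on a carbonyl carbon. In short, 1-(4-isobutylphenyl)ethyl stands in place of 2-acetoxyphenyl on a carbonyl carbon.

Within the data shown here, the one measured step that touches compound 3 is a step that the two limits leave unreadable from compound 2 to compound 3. It exchanges methyl for (2-acetoxyphenyl)carbonyl on an oxygen on a saturated carbon, so it is a different change and offers no size to carry over. Among the measured compounds shown here, the only guide is thin: both compounds carrying the 2-acetoxyphenyl group sit at the limit of > 10000 nM in this assay, at which 2 of the 3 values shown sit, while compound 1, which lacks that group, reaches 3200 nM. On that basis, a move towards stronger inhibition in this assay is expected, though a reading that again returns only a limit remains quite possible. The expected change is an at least 1.6-fold lower number from compound 3 to compound 4 (0.22 log units; that floor lies within the scatter), and its size is uncertain with compound 3 known only as a limit. For compound 4 the estimated value is 6000 nM, with an expected range of 2500 nM to 15000 nM.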

Compound 4, half-maximal inhibitory concentration: > 10000 nM
Compound 4 was reported as a limit; the forecaster's own chance of this, stated with the estimate: 40%; at least 1.6-fold (0.22 log units) between middle value and limit.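

Compound 4 gives > 10000 nM in this assay, which is a limit and not a number. Compound 3 is also known only as a limit, so no step can be read between compound 3 and compound 4. The compounds shown leave open whether 1-(4-isobutylphenyl)ethyl and 2-acetoxyphenyl on that carbonyl carbon differ at all in this read-out, as both compounds stand at one ceiling: the limit of > 10000 nM in this assay, at which 3 of the 4 values shown sit.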